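Substance-P receptor series: aryl groups on the indole-type core

A few compounds are considered here, and "the series" means these few. Any claim that something is new, unique, unknown or untested is made for them only; others in the source may bear on it.

Measured compounds in an assay on CHO cells for displacement of a labelled ligand from Substance-P receptor (Homo sapiens); a higher number here means a weaker inhibitor, a lower number a stronger inhibitor:
compound 1 `Cn1c(-c2ccc(Cl)cc2)c(CCC(=O)N2CCC(O)(Cc3ccccc3)CC2)c2cc(Cl)ccc21`, 0.16 nM
compound 2 `CC(=O)c1ccc2c(c1)c(CCC(=O)N1CCC(O)(Cc3ccccc3)CC1)c(-c1ccc(Cl)cc1)n2C`, 0.19 nM
compound 3 `Cn1c(-c2ccc(Cl)cc2)c(CCC(=O)N2CCC(O)(Cc3ccccc3)CC2)c2cc(-c3ccco3)ccc21`, 0.79 nM

Compound 3 gives the highest number of the three in this assay; the nearest is compound 2, the furthest compound 1. Both measured steps onto compound 3 run the same way: a 4.9-fold higher number from compound 1 to compound 3 (0.69 log units; beyond the scatter), and a 4.2-fold higher number from compound 2 to compound 3 (0.62 log units; beyond the scatter). Between compound 1 and compound 2 the step is a 1.2-fold higher number from compound 1 to compound 2 (0.07 log units; within the scatter), so chloro and acetyl at that place give numbers that cannot be told apart, while furan-2-yl at the same place costs a modest amount.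

Compound 4 `Cn1c(-c2ccc(Cl)cc2)c(CCC(=O)N2CCC(O)(Cc3ccccc3)CC2)c2cc(-c3ccncc3)ccc21` carries the change (pyridin-4-yl in place of furan-2-yl on an aromatic carbon). For the measured compounds named here, no measured step leads from one aromatic ring at this place to another; the two steps that bear on it, from compound 1 and from compound 2 to compound 3, only show that an aromatic ring with one hetero atom at this place gives a modestly higher number than chloro or acetyl. Pyridin-4-yl brings the same count of acceptors and donors as furan-2-yl, with one more heavy atom and a six-membered ring. For compound 4 the expectation is therefore a step of about a 1.1-fold higher number from compound 3 to compound 4 (0.06 log units; within the scatter) in this assay, most likely not beyond the scatter in either direction. The estimate for compound 4 in this assay is 0.9 nM, with a range from 0.3 nM to 2.7 nM.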

Compound 4, half-maximal inhibitory concentration: 5.5 nM
The estimate for compound 4 lay 6.1-fold (0.79 log units) below the measured number; the whole stated range lies below it.
By their numbers in this assay, from the lowest: compounds 1 and 2 (each within the scatter of the next); then compound 3; then compound 4.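

In this assay, this position distinguishes between two aromatic rings that have the same counts of donors and acceptors: the result is a 7.0-fold higher number from compound 3 to compound 4 (0.84 log units; beyond the scatter) for this exchange alone. The earlier compounds shown here showed only that furan-2-yl gave a modestly higher number than chloro or acetyl, whereas pyridin-4-yl gives a large step from each of them, with a 29-fold higher number from compound 2 to compound 4 (1.46 log units; beyond the scatter) and a 34-fold higher number from compound 1 to compound 4 (1.54 log units; beyond the scatter) in the same direction. The evidence at hand gives no cause for the difference between the two rings.

Pyridin-4-yl and furan-2-yl differ at once in ring size and in the hetero atom, so the compounds shown cannot assign the step to either feature. Phenyl would show the six-membered ring without a hetero atom, while pyridin-3-yl would show the effect of moving the ring nitrogen and thiophen-2-yl that of replacing the furan oxygen with sulfur in a five-membered ring.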